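The source may report more compounds than this note shows. Statements on the series, on what has been measured and on what is new or still open speak of the compounds shown alone.

In a functional assay on KM12 cells (Homo sapiens) for inhibition, read by sulforhodamine B assay, with a stated time of 48 h (on this read-out higher numbers stand for lower toxicity in this test and lower numbers for higher toxicity in this test), three compounds have been measured:

Compound 1, `O=C(Nc1cccc(-n2cc(-c3ccncc3)c(-c3ccc(Cl)c(O)c3)n2)c1)Nc1ccc(Cl)c(Cl)c1`: 26300 nM
Compound 2, `O=C(Nc1cccc(-n2cc(-c3ccncc3)c(-c3ccc(Cl)c(O)c3)n2)c1)Nc1cc(C(F)(F)F)cc(C(F)(F)F)c1`: 4060 nM
Compound 3, `COc1cc(-c2nn(-c3cccc(NC(=O)Nc4ccc(Cl)c(C(F)(F)F)c4)c3)cc2-c2ccncc2)ccc1Cl`: 14900 nM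

Compound 2 gives the lowest number of the three. The nearest neighbour on this read-out is compound 3, whose number lies beyond the scatter above that of compound 2, and compound 1 stands further still, also beyond the scatter. No two of these compounds differ in a single place, so no step can be traced between them; only the values themselves can be compared.

Compound 4, `O=C(Nc1cccc(-n2cc(-c3ccncc3)c(-c3ccc(Cl)c(O)c3)n2)c1)Nc1cccc(C(F)(F)F)c1`, has not yet been measured in this assay. It is derived from compound 2 by one change: hydrogen in place of trifluoromethyl on an aromatic carbon

The shared core and the urea are kept, and only one of the two trifluoromethyl groups is removed. With the number of compound 2 standing lowest and both other compounds higher, the expectation for compound 4 is a modest rise, a step from compound 2 to compound 4 of about a 2.2-fold higher number from compound 2 to compound 4 (0.35 log units; beyond the scatter) in this assay, though a step within the scatter cannot be ruled out. Compound 4 is thus estimated at 9000 nM, with a range from 3000 nM to 27000 nM.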

Compound 4, concentration lethal to 50% of the cells: > 32500 nM
Compound 4 gave a limit, no number; the forecaster's own chance of this, stated with the estimate: 5%; middle value at least 3.6-fold (0.55 log units) away from the limit.
By their numbers in this assay, from the lowest: compound 2; then compounds 3 and 1 (each within the scatter of the next). At a limit, above all of these: compound 4.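

In this assay, going by these compounds alone, hydrogen in place of trifluoromethyl at this position gives an at least 8.0-fold higher number from compound 2 to compound 4 (0.90 log units; beyond the scatter), so the single trifluoromethyl group left on the ring of compound 4 does not keep the low number of compound 2. With 3-(trifluoromethyl)phenyl in place of 3,4-dichlorophenyl, the pair shows an at least 1.2-fold higher number from compound 1 to compound 4 (0.09 log units; that floor lies within the scatter), so this change does not separate compound 1 from compound 4 in this assay. Both steps are floors, not measured sizes: the limit of > 32500 nM in this assay, at which 1 of the 4 values shown sits.

The compounds shown leave open how a smaller replacement at this position, such as a methoxy group, a nitrile or an amine, would read in this assay, and so whether trifluoromethyl is needed there or any group would serve. On these data alone, the actual size of the step from compound 2 to compound 4 also stays open.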